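The compounds below may be only part of what the source reports. "The series", "measured", "known", "first", "only" and "open" are said of these compounds alone.

Measured in a functional assay on KM12 cells (Homo sapiens) for antiproliferative activity; a higher number here means a weaker inhibitor of growth, a lower number a stronger inhibitor of growth:
Compound 1 `COc1ccc(-c2nc3cc(F)ccc3s2)cc1OC`: 290 nM
Compound 2 `COc1cc(-c2nc3cc(F)ccc3s2)cc(OC)c1OC`: 13000 nM

Of these two, compound 2 stands higher at 13000 nM, making it the weaker inhibitor of growth. For the measured compounds named here, the only measured step is a 45-fold higher number from compound 1 to compound 2 (1.65 log units; beyond the scatter), and it came with methoxy in place of hydrogen on an aromatic carbon.

Compound 3 `COc1cc(-c2nc3cc(F)ccc3s2)cc(O)c1OC` departs from compound 2 by hydrogen in place of methyl on an oxygen on an aromatic ring, or methoxy to hydroxy. Going by the values given here, no measured step shows this change directly. The nearest guide is a 45-fold higher number from compound 1 to compound 2 (1.65 log units; beyond the scatter), since compound 3 carries hydroxy where compound 2 has methoxy and compound 1 has hydrogen. On that reading, compound 3 is expected to fall between its two relatives in this assay, recovering part of that large step, though the data do not show how much. The expected change is a 6.5-fold lower number from compound 2 to compound 3 (0.81 log units; beyond the scatter), a moderate move to a lower number. For compound 3 the estimated value is 2000 nM, with an expected range from 300 nM to 13000 nM.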

Compound 3, concentration for 50% growth inhibition: 47500 nM
Compound 3: middle estimate off by 24-fold (1.38 log units), on the low side; the whole stated range lies below it.
By their numbers in this assay, from the lowest: compound 1; then compound 2; then compound 3.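

In this assay, the change from methoxy to hydroxy did not move the number back toward compound 1: the step is a 3.7-fold higher number from compound 2 to compound 3 (0.56 log units; beyond the scatter) and so runs in the same direction as the earlier addition of methoxy. Measured from the hydrogen of compound 1, the addition of hydroxy gives a 160-fold higher number from compound 1 to compound 3 (2.21 log units; beyond the scatter) and goes further than a 45-fold higher number from compound 1 to compound 2 (1.65 log units; beyond the scatter) does, so at this place on the ring compound 1, with hydrogen, is the strongest inhibitor of growth of the three, compound 2, with methoxy, comes next, and compound 3, with hydroxy, is the weakest. No independent measurement is available to explain this order.

The compounds shown leave open how other groups would behave at this place, such as an amine, a carboxylic acid, a fluorine atom or a longer chain on the oxygen. They also leave open whether the same order of hydrogen, methoxy and hydroxy would hold if the fluorine on the shared core or the other two methoxy groups were changed.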